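Removing the aromatic methyl: compound 3 to compound 4

The source may hold more compounds than are shown below. What is called first, only, known or untested is meant among the compounds shown, and "the series" means these compounds.

Measured compounds:
compound 1 `Cn1c(-c2ccc(F)cc2)nc2c(NC3CCCC3)ncnc21`; in a functional assay on CHO cells for antagonist activity at adenosine receptor A1 (Homo sapiens), read by cAMP accumulation, with a stated time of 10 min (a lower number here means a stronger inhibitor, a higher number a weaker inhibitor), compound 1 gives 32 nM
compound 2 `Cn1c(-c2ccc(O)cc2)nc2c(NC3CCCC3)ncnc21`; in this assay compound 2 gives 52 nM
compound 3 `Cc1ccc(-c2nc3c(NC4CCCC4)ncnc3n2C)cc1`; in this assay compound 3 gives 61 nM

Compound 3 carries the highest of the three numbers, but its distances to the others are small: a 1.2-fold higher number from compound 2 to compound 3 (0.07 log units; within the scatter) and a 1.9-fold higher number from compound 1 to compound 3 (0.28 log units; within the scatter). Neither separation is beyond the scatter, so no order among the three can be read from these values.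

Compound 4 `Cn1c(-c2ccccc2)nc2c(NC3CCCC3)ncnc21` differs from compound 3 in one place: hydrogen in place of methyl on an aromatic carbon. The change sits on the same aromatic carbon that distinguishes all three measured compounds from one another, so all three measured steps bear on it. Each of them was small: a 1.6-fold higher number from compound 1 to compound 2 (0.21 log units; within the scatter), a 1.9-fold higher number from compound 1 to compound 3 (0.28 log units; within the scatter), a 1.2-fold higher number from compound 2 to compound 3 (0.07 log units; within the scatter). Fluoro, hydroxy and methyl at this position give numbers that cannot be told apart within the usual scatter. Replacing methyl with hydrogen is a change of the same kind at the same site, and nothing in the measured steps points to a direction. The expected step in this assay is therefore none beyond the scatter, a 1.2-fold lower number from compound 3 to compound 4 (0.09 log units; within the scatter).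

Compound 4 is estimated at 50 nM in this assay, with a range from 20 nM to 130 nM.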

Compound 4, half-maximal inhibitory concentration: 14 nM
For compound 4 the middle estimate is 3.6-fold (0.55 log units) above the measured one, outside the stated range (below it).
By their numbers in this assay, from the lowest: compound 4; then compounds 1, 2 and 3 (each within the scatter of the next).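

In this assay this carbon of the six-membered aromatic ring, para to a large group, proves sensitive to substitution after all: the steps to hydrogen read a 4.4-fold lower number from compound 3 to compound 4 (0.64 log units; beyond the scatter) for loss of methyl, a 3.7-fold lower number from compound 2 to compound 4 (0.57 log units; beyond the scatter) for loss of hydroxy and a 2.3-fold lower number from compound 1 to compound 4 (0.36 log units; beyond the scatter) for loss of fluoro, all beyond the scatter. The earlier agreement among fluoro, hydroxy and methyl therefore holds only among the substituted compounds, and compound 4 is the strongest inhibitor of the four, with all three groups going the same way against hydrogen and no compound shown going against this. Nothing available here accounts for why the unsubstituted phenyl gives the lowest number.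

From the compounds shown here alone, it remains open whether other groups on this carbon, such as an amine, a carboxylic acid or a longer chain, would stay level with fluoro, hydroxy and methyl, move further from hydrogen or match it. Also open, going by these compounds, is whether the change from 4-methylphenyl to phenyl gives a step of similar size when the rest of the shared core is altered.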